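Urea to Amide Swap in a Cell Growth Inhibition Series

The compounds below may be only part of what the source reports. "The series", "measured", "known", "first", "only" and "open" are said of these compounds alone.

Measured so far:
Compound 1, `COc1cc(Cl)cc(-c2nn(-c3cccc(NC(=O)Nc4ccc(Cl)c(Cl)c4)c3)cc2-c2ccncc2)c1`: 7%
Compound 2, `COc1cc(Cl)cc(-c2nn(-c3cccc(NC(=O)Nc4cccc(C(F)(F)F)c4)c3)cc2-c2ccncc2)c1`: -11%

Both compounds share one core and differ only in the group attached through the urea nitrogen. In a functional assay on SW-620 cells (Homo sapiens) for inhibition, read by sulforhodamine B assay, with a stated time of 48 h, tested at 100 uM (a higher number here means a weaker effect of the compound at the concentration tested, a lower number a stronger effect), compound 1 gives 7%, and compound 2 gives -11%. Among the compounds with values here, the one measured step, a number 18 percentage points lower from compound 1 to compound 2 (beyond the scatter), leaves compound 2 with the lowest of the two numbers, its nearest neighbour being compound 1.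

Compound 3, `COc1cc(Cl)cc(-c2nn(-c3cccc(NC(=O)c4cccc(C(F)(F)F)c4)c3)cc2-c2ccncc2)c1`, is the next compound to be measured. Compared with compound 2 the change is 3-(trifluoromethyl)phenyl in place of (3-(trifluoromethyl)phenyl)amino on a carbonyl carbon, so the urea of compound 2 becomes an amide while the 3-(trifluoromethyl)phenyl group stays.

Within the data shown here, no measured step touches this part of the molecule: the only step known, a number 18 percentage points lower from compound 1 to compound 2 (beyond the scatter), swaps one aryl group for another on the same nitrogen and keeps the urea intact. There is therefore no direct guide, and the two measured values already sit near zero. A step of a number 14 percentage points higher from compound 2 to compound 3 (beyond the scatter) is expected, which stays within the scatter. Compound 3 is expected to give about 3%, between -20% and 28%.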

Compound 3, a percentage reported as activity, at one concentration (the size of the read-out at that concentration, not a potency): 57%
For compound 3 the middle estimate is 54 percentage points below the measured one; measured number outside the range, above it.
By their numbers in this assay, from the lowest: compound 2; then compound 1; then compound 3.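

In this assay, replacing (3-(trifluoromethyl)phenyl)amino with 3-(trifluoromethyl)phenyl on the carbonyl carbon turns the urea into an amide and gives a number 68 percentage points higher from compound 2 to compound 3 (beyond the scatter), so the effect at the tested concentration is much weaker without that nitrogen. Compound 1 differs from compound 3 in its aryl group as well as in the urea, and that comparison gives a number 50 percentage points higher from compound 1 to compound 3 (beyond the scatter); both steps are large, whereas the earlier change of aryl group on the intact urea was modest, so in these three compounds the urea link counts for more than the aryl groups compared. The change removes a nitrogen and the hydrogen-bond donor counted on the departing group, but nothing available connects either loss to the weaker effect.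

On these data alone, it remains open whether the nitrogen itself or its hydrogen matters, which a methyl group on that nitrogen or an oxygen in its place, as in a carbamate, could help to separate. As far as these compounds go, it is also open whether 3,4-dichlorophenyl directly on the carbonyl carbon would behave like compound 3.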